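The source may report more compounds than this note shows. Statements on the series, on what has been measured and on what is new or still open speak of the compounds shown alone.

Measured so far:
Compound 1, `CCCCCCCCCCCCNc1nc(SCc2ccc(C(F)(F)F)cc2)nc2ccccc12`: in a functional assay on HGC-27 cells (Homo sapiens) for cytotoxicity, read by MTT assay, with a stated time of 72 h (on this read-out lower numbers stand for stronger inhibition and higher numbers for weaker inhibition), compound 1 gives 38700 nM.
Compound 2, `COc1ccccc1Nc1nc(SCc2ccc(C(F)(F)F)cc2)nc2ccccc12`: in this assay compound 2 gives > 50000 nM, which is a limit of the assay and not a number.

The two compounds share one core and differ only in the group carried on the nitrogen: a long chain in compound 1, an aromatic ring bearing a methoxy group in compound 2. Compound 2 stands at the weak end of what is shown, since its result is a limit, one of the two values sitting there (the limit of > 50000 nM in this assay, at which 1 of the 2 values shown sits), so no exact number can be placed beside it.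

Compound 3, `Fc1ccc(Nc2nc(SCc3ccc(C(F)(F)F)cc3)nc3ccccc23)cc1`, has not yet been measured. It differs from compound 2 in one place: 4-fluorophenyl in place of 2-methoxyphenyl on a nitrogen on an aromatic ring. An aromatic ring stays on the nitrogen; only its substituent changes. Among the measured compounds shown here, no measured step between related compounds is available to guide the size of this move, so the step from compound 2 to compound 3 is expected to be an at least 1.1-fold lower number from compound 2 to compound 3 (0.04 log units; that floor lies within the scatter), not clearly beyond the scatter. Compound 3 is therefore estimated at 45000 nM, within 18000 nM to 110000 nM, with a real chance that this assay again reports only a limit.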

Compound 3, half-maximal inhibitory concentration: 19500 nM
The estimate for compound 3 lay 2.3-fold (0.36 log units) above the measured number; the measured number falls inside the stated range.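

In this assay, placing 4-fluorophenyl where 2-methoxyphenyl stood on a nitrogen on an aromatic ring gives an at least 2.5-fold lower number from compound 2 to compound 3 (0.40 log units; beyond the scatter), so what the ring carries matters here, and not only the presence of a ring on this nitrogen. Compound 2 gives > 50000 nM, which is a limit of the assay and not a number. The step therefore gives only the smallest size the change can have, and the true change may be larger, because its starting point is not an exact value: the limit of > 50000 nM in this assay, at which 1 of the 3 values shown sits.

This swap changes two things at once, the substituent and where it sits on the ring, so the compounds shown cannot tell which of the two accounts for the step; a 2-fluorophenyl or a 4-methoxyphenyl group on the same nitrogen would separate them. A plain phenyl ring would show whether the fluorine helps, the methoxy group hurts, or both, and nothing here explains why the change moves the number.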